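The source may hold more compounds than are shown below. What is called first, only, known or untested is meant among the compounds shown, and "the series" means these compounds.

Measured in an ADME assay on HCT-116 cells (Homo sapiens) for cytotoxicity, read by CellTiter-Glo, with a stated time of 72 h; on this read-out lower numbers stand for stronger inhibition and higher numbers for weaker inhibition:

compound 1 `CC1CCN(C2CCN(S(=O)(=O)c3ccc(Cl)nc3)CC2)CC1`: > 10000 nM
compound 2 `CCCOc1ccc(S(=O)(=O)N2CCC(N3CCC(C)CC3)CC2)cc1`: > 5000 nM
compound 3 `CC1CCN(C2CCN(S(=O)(=O)c3ccc(Br)c(Cl)c3)CC2)CC1`: > 5000 nM

None of these three entries is an exact number. Compound 1 gives > 10000 nM, which is a limit of the assay. Compound 2 gives > 5000 nM, also a limit. Compound 3 gives > 5000 nM, again a limit, so it has no exact position among the others. It shares (the limit of > 5000 nM in this assay, at which 2 of the 3 values shown sit).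

The next compound is compound 4 `CCc1ccc(S(=O)(=O)N2CCC(N3CCC(C)CC3)CC2)cc1`. It carries 4-ethylphenyl in place of 4-bromo-3-chlorophenyl on a sulfonyl sulfur.

Among the compounds with values here, the one measured step that changes the group at this place is a step that the two limits leave unreadable from compound 1 to compound 3. Both of its ends are limits, so it offers no size to carry over to the new change. The expectation therefore rests on compound 3 and its > 5000 nM, together with the limit of > 10000 nM in this assay, at which 1 of the 3 values shown sits. Within the data shown here, no compound measured so far has reached a readable number in this assay, so compound 4 is expected to show no clear inhibition either, and quite possibly to return only a limit. The expected change is a step that the limit leaves unreadable from compound 3 to compound 4, with no step beyond the usual scatter foreseen. For compound 4 the estimate is 8000 nM, with an expected range from 4000 nM to 20000 nM.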

Compound 4, half-maximal inhibitory concentration: > 5000 nM
Compound 4 was reported as a limit (the forecaster's own chance of this, stated with the estimate: 85%); the middle value is on the limit's open side.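

In this assay compound 4 gives > 5000 nM, which is a limit of the assay and not a number. Compound 1, compound 2 and compound 3 also gave only limits, so the steps from them to compound 4 cannot be read. The compounds shown leave open whether any group on the sulfonyl sulfur changes the read-out at all.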